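Oxopiperidinyl in Place of Fluorophenylamino on the Core

The source may hold more compounds than are shown below. What is called first, only, known or untested is meant among the compounds shown, and "the series" means these compounds.

Compound 1 `CC(C(=O)NCc1ccc(C(F)(F)F)nc1Nc1ccc(F)cc1)c1ccc(NS(C)(=O)=O)c(F)c1` gives 39.2 nM in a functional assay on CHO-K1 cells for antagonist activity at transient receptor potential cation channel subfamily V member 1 (Homo sapiens), read by FLIPR (a lower number here means a stronger inhibitor, a higher number a weaker inhibitor), the highest of the two numbers in hand. Compound 2 `CC(C(=O)NCc1ccc(C(F)(F)F)nc1N1CCC(Cc2ccc(F)c(F)c2)CC1)c1ccc(NS(C)(=O)=O)c(F)c1` gives 0.2 nM in this assay, a gap from compound 1 that lies beyond the usual scatter. Among the measured compounds shown here, no step between two measured compounds that differ in one place is available, so the direction of the change toward compound 3 rests on the structures alone. Compound 3 `CC(C(=O)NCc1ccc(C(F)(F)F)nc1N1CCC(=O)CC1)c1ccc(NS(C)(=O)=O)c(F)c1` carries 4-oxopiperidin-1-yl in place of (4-fluorophenyl)amino on an aromatic carbon. The group that enters is smaller than the group that leaves and drops the aromatic ring and the hydrogen-bond donor, whereas compound 2, the only stronger inhibitor here, reaches 0.2 nM with a larger ring-bearing group on the aromatic carbon next to the ring nitrogen. For compound 3 a step toward a weaker inhibitor is expected, a 2.6-fold higher number from compound 1 to compound 3 (0.41 log units; beyond the scatter), modest against the scatter. Compound 3 is estimated at 100 nM, with a range from 20 nM to 500 nM.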

Compound 3, inhibition constant: 91 nM
The estimate for compound 3 lay 1.1-fold (0.04 log units) above the measured number; low and high end bracket the measured number.
By their numbers in this assay, from the lowest: compound 2; then compound 1; then compound 3.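

In this assay, placing 4-oxopiperidin-1-yl in place of (4-fluorophenyl)amino on this aromatic carbon, next to the ring nitrogen, gives a 2.3-fold higher number from compound 1 to compound 3 (0.37 log units; beyond the scatter). The step is modest, so neither the aromatic ring of the leaving group nor its hydrogen-bond donor is needed for inhibition at this position: without both, compound 3 still gives 91 nM. No measurement bears on what lies behind the step, and it cannot be assigned to any single feature of the exchange.

Going by these compounds, the share of the carbonyl in this result remains open, and a plain piperidin-1-yl or a morpholin-4-yl group on the same carbon would test it. Also open, on these data alone, is how a 4-hydroxypiperidin-1-yl group would stand against the ketone.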